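The source may report more compounds than this note shows. Statements on the series, on what has been measured and on what is new or still open speak of the compounds shown alone.

Compound 2 `COc1cc(-c2nn(-c3cccc(NC(=O)Nc4ccc(Cl)c(Cl)c4)c3)cc2-c2ccncc2)ccc1Cl` holds the only number shown in a functional assay on TK-10 cells (Homo sapiens) for inhibition, read by sulforhodamine B assay, with a stated time of 48 h; on this read-out higher numbers stand for weaker inhibition of growth and lower numbers for stronger inhibition of growth: in this assay compound 2 gives 40900 nM. Compound 1 `O=C(Nc1cccc(-n2cc(-c3ccncc3)c(-c3ccc(Cl)c(O)c3)n2)c1)Nc1cccc(C(F)(F)F)c1` returns no number in this assay, only > 32500 nM, which is a limit of the assay (the limit of > 32500 nM in this assay, at which 1 of the 2 values shown sits). Compound 3 `O=C(Nc1cccc(-n2cc(-c3ccncc3)c(-c3ccc(Cl)c(O)c3)n2)c1)Nc1ccc(Cl)c(Cl)c1` differs from compound 2 by hydrogen in place of methyl on an oxygen on an aromatic ring. Among the measured compounds shown here, no measured pair carries this change, and the step expected here, a 1.0-fold lower number from compound 2 to compound 3 (0.01 log units; within the scatter), lies within the usual scatter. Compound 3 is therefore estimated at 40000 nM, with a range from 15000 nM to 100000 nM.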

Compound 3, concentration for total growth inhibition: > 32500 nM
Compound 3: no number, only a limit; the forecaster's own chance of this, stated with the estimate: 40%; the middle value does not contradict the limit.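

No step can be read from compound 2 to compound 3 or from compound 1 to compound 3, because compound 3 gives only a limit of the assay: the limit of > 32500 nM in this assay, at which 2 of the 3 values shown sit.

The compounds shown leave open whether methoxy to hydroxy, or 3,4-dichlorophenyl in place of 3-(trifluoromethyl)phenyl, changes the result in this assay at all.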